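The source may report more compounds than this note shows. Statements on the series, on what has been measured and on what is new or still open speak of the compounds shown alone.

In an assay on isolated protein (Oryctolagus cuniculus) with Thromboxane-A synthase (Homo sapiens) as the target, tested at 1 uM (on this read-out lower numbers stand for less inhibition and higher numbers for more inhibition at the one concentration tested (going by the name of the read-out)), compound 1 `O=c1c2ccccc2c(-c2cccnc2)nn1C1CCCC1` gives 97%. Among the compounds with values here, the only other measured compound, compound 2 `COC(=O)c1ccc(Cn2nc(-c3cccnc3)c3ccccc3c2=O)cc1`, gives 95% in this assay. The number for compound 1 is the higher of the two, but the two values lie within the usual scatter of repeated measurements of each other, so they cannot be told apart.

Compound 3 `O=C(c1cccs1)n1nc(-c2cccnc2)c2ccccc2c1=O` has not been measured. It differs from compound 1 in one place: (thiophen-2-yl)carbonyl in place of cyclopentyl on an aromatic nitrogen. Within the data shown here, no step between two measured compounds covers this kind of change, so there is nothing to lean on beyond the two values themselves, both of which stand near the top of what this assay can report. The expected step in this assay is a number 9 percentage points lower from compound 1 to compound 3 (within the scatter), a modest drop that may still fall inside the scatter. For compound 3 the estimate is 88%, with a range from 70% to 99%.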

Compound 3, a percentage reported as inhibition, at one concentration (the size of the read-out at that concentration, not a potency): 37%
Estimate against measurement, compound 3: 51 percentage points above; measured number below the stated range.
By their numbers in this assay, from the lowest: compound 3; then compounds 2 and 1 (each within the scatter of the next).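

In this assay, putting (thiophen-2-yl)carbonyl in place of cyclopentyl on the aromatic nitrogen gives a number 60 percentage points lower from compound 1 to compound 3 (beyond the scatter). The values that came before sat close together near the top of the read-out and gave no sign that the group on this nitrogen matters, whereas this single change shows that inhibition at the one concentration tested can depend strongly on it. Nothing measured here explains the drop.

The step brings in a carbonyl and a thiophene ring together, so the compounds shown cannot tell which of the two goes with the lower number. A cyclopentylcarbonyl group, which keeps the carbonyl without the thiophene, or a thiophen-2-ylmethyl group, which keeps the thiophene without the carbonyl, would pull the two apart.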